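A 3-Phenylphenyl Group Added to a Non-Toxic Ester

The source may hold more compounds than are shown below. What is called first, only, known or untested is meant among the compounds shown, and "the series" means these compounds.

Compound 3 `CCOC(=O)CCCCCOc1cccc(CN(C(=O)c2ccccc2)C(C)C)c1` carries an ethyl ester and an isopropyl amide on the shared core. In an ADME assay on HEK293 cells (Homo sapiens) for cytotoxicity, read by CellTiter-Glo and resazurin assay, with a stated time of 72 h (on this read-out higher numbers stand for an effect only at larger amounts of compound and lower numbers for an effect already at smaller amounts), compound 3 gives > 26000 nM, which is a limit of the assay rather than a number. Compound 1 `CC(C)N(Cc1cccc(OCCCCCC(=O)O)c1)C(=O)c1ccccc1` lacks the ethyl group. In this assay compound 1 gives > 26000 nM, again a limit. Compound 2 `COc1ccc(F)c(-c2ccc(C(=O)N(Cc3cccc(OCCCCCC(=O)O)c3)C(C)C)cc2)c1` instead carries a 2-fluoro-5-methoxyphenyl on an aromatic carbon. In this assay compound 2 gives > 26000 nM, also a limit. Both measured steps, a step that the two limits leave unreadable from compound 1 to compound 3 and a step that the two limits leave unreadable from compound 1 to compound 2, stay unreadable due to the limit of > 26000 nM in this assay, at which 3 of the 3 values shown sit. Compound 4 `CCOC(=O)CCCCCOc1cccc(CN(C(=O)c2ccc(-c3cccc(-c4ccccc4)c3)cc2)C(C)C)c1` differs from compound 3 by 3-phenylphenyl in place of hydrogen on an aromatic carbon. The two measured steps bear on this move, and neither could be sized, so no step beyond the scatter is expected, and the step that the limit leaves unreadable from compound 3 to compound 4 is estimated on that basis. For compound 4 in this assay the expected value is 30000 nM, within 12000 nM to 80000 nM, and most likely it is again reported only as a limit.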

Compound 4, half-maximal effective concentration: > 26000 nM
Compound 4 gave a limit, no number; the forecaster's own chance of this, stated with the estimate: 80%; the middle value does not contradict the limit.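

No new step can be read from compound 3 to compound 4, because in this assay both give only a limit: the limit of > 26000 nM in this assay, at which 4 of the 4 values shown sit. The compounds shown leave open at what concentration any of them affects these cells, and whether adding 3-phenylphenyl changes that concentration.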